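The source may hold more compounds than are shown below. What is called first, only, known or untested is meant among the compounds shown, and "the series" means these compounds.

Compound 1 `O=C(Nc1ccc(I)cc1)N[C@H]1CC[C@H](Oc2ccc(F)cc2)CC1` is the most recent anchor of this series of aryl ureas on a shared cyclohexyl ether core. In a functional assay on CRL2813 cells (Homo sapiens) for cytotoxicity, read by sulforhodamine B assay, with a stated time of 5 days (a higher number here means a weaker inhibitor, a lower number a stronger inhibitor), compound 1 gives 10200 nM, which is the higher of the two numbers reported for this set. Its nearest neighbour is compound 3 `O=C(Nc1cccc(F)c1)N[C@H]1CC[C@H](Oc2ccc(F)cc2)CC1`, which in this assay gives 8300 nM; the step of a 1.2-fold lower number from compound 1 to compound 3 (0.09 log units; within the scatter) shows that exchanging the aryl group on the urea nitrogen did not move the number beyond the scatter. Compound 2 `O=C(Nc1cccc(C(F)(F)F)c1)N[C@H]1CC[C@H](O)CC1` is reported in this assay only as a limit, > 20000 nM, and not as a number.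

Compound 4 `O=C(Nc1ccc(Br)cc1)N[C@H]1CC[C@H](Oc2ccc(F)cc2)CC1` has not yet been measured. It differs from compound 1 in a single place: bromo in place of iodo on an aromatic carbon. Among the measured compounds shown here, the only measured step that bears on this kind of change is the aryl exchange from compound 1 to compound 3, and that step stayed within the scatter. A small exchange on the same aromatic ring is therefore expected to produce no step beyond the scatter in this assay either. Compound 4 is accordingly expected to give about 10000 nM, with a range from 5000 nM to 20000 nM, which corresponds to an expected step of a 1.0-fold lower number from compound 1 to compound 4 (0.01 log units; within the scatter).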

Compound 4, half-maximal inhibitory concentration: > 20000 nM
Compound 4: a limit, no number; the forecaster's own chance of this, stated with the estimate: 25%; at least 2.0-fold (0.30 log units) between middle value and limit.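

In this assay compound 4 is reported only as a limit, > 20000 nM, and not as a number, so the exchange of iodo for bromo at this position has no exact size. The step reads as an at least 1.9-fold higher number from compound 1 to compound 4 (0.29 log units; that floor lies within the scatter), which means that this single-atom exchange may be small or may be much larger, whereas the earlier aryl exchange had a measured size and stayed within the scatter. The second new step, an at least 2.4-fold higher number from compound 3 to compound 4 (0.38 log units; beyond the scatter), shows for the first time that with the rest of compound 3 unchanged, the aryl group on the urea nitrogen can separate two compounds by more than the scatter, and compound 4 now joins the set's other reading at the limit: the limit of > 20000 nM in this assay, at which 2 of the 4 values shown sit.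

As far as these compounds go, what remains open is how far the true value of compound 4 lies past its limit, and therefore whether iodo at this position truly differs from bromo. The compounds shown also leave open whether chloro, a methoxy group or a nitrile in the same place would give a readable number, and whether an unsubstituted phenyl would do so.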